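Indole-oxazole series: removing the aryl substituent

The compounds below may be only part of what the source reports. "The series", "measured", "known", "first", "only" and "open" are said of these compounds alone.

Measured so far:
Compound 1, `Cc1nc(-c2c[nH]c3ccccc23)co1` — 337000 nM
Compound 2, `Fc1ccc(-c2nc(-c3c[nH]c4ccccc34)co2)cc1` — 42800 nM
Compound 3, `COc1ccc(-c2nc(-c3c[nH]c4ccccc34)co2)cc1` — 133000 nM

In a functional assay on PC-3 cells (Homo sapiens) for cytotoxicity, read by MTT assay, with a stated time of 48 h (on this read-out lower numbers stand for stronger inhibition and higher numbers for weaker inhibition), compound 2 gives the lowest of the three numbers. Its nearest neighbour is compound 3, a 3.1-fold higher number from compound 2 to compound 3 (0.49 log units; beyond the scatter); the furthest is compound 1, which stands a 7.9-fold lower number from compound 1 to compound 2 (0.90 log units; beyond the scatter) above it.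

Compound 4, `c1ccc2c(-c3cocn3)c[nH]c2c1`, is not yet measured. It differs from compound 2 in one place: hydrogen in place of 4-fluorophenyl on an aromatic carbon.

Among the measured compounds shown here, the only step that bears on this change is the one from compound 1 to compound 2, where a small group on the shared core was exchanged for the 4-fluorophenyl group and gave a 7.9-fold lower number from compound 1 to compound 2 (0.90 log units; beyond the scatter). Compound 4 goes further in the opposite direction, carrying no group at all on that carbon. The expectation is therefore a step upward in this assay at least as large as the reverse of that one, placing compound 4 near or above compound 1.

Compound 4 is estimated at 400000 nM, with a range of 150000 nM to 1100000 nM, which means an expected step of a 9.3-fold higher number from compound 2 to compound 4 (0.97 log units; beyond the scatter).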

Compound 4, half-maximal inhibitory concentration: 321000 nM
Estimate against measurement, compound 4: 1.2-fold (0.10 log units) above, within the range that was stated.
By their numbers in this assay, from the lowest: compound 2; then compound 3; then compounds 4 and 1 (each within the scatter of the next).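

In this assay, hydrogen in place of 4-fluorophenyl on this carbon gives a 7.5-fold higher number from compound 2 to compound 4 (0.88 log units; beyond the scatter) and so sets the aryl group against an empty position as well as against methyl. Hydrogen in place of methyl gives a 1.0-fold lower number from compound 1 to compound 4 (0.02 log units; within the scatter) and so does not separate these two small substituents on this read-out, which leaves the low number of compound 2 tied to the 4-fluorophenyl group among the groups compared here. Nothing at hand accounts for the difference between the 4-fluorophenyl group and these small substituents.

Going by these compounds, whether plain phenyl, without the fluoro substituent, keeps the number of compound 2 remains open. Also open, on these data alone, is whether an amine, a carboxylic acid or a longer alkyl chain on this carbon would read like hydrogen or like the aryl compounds.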